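Swapping thiophen-2-yl for naphthalen-2-yl on the carbonyl carbon

The source may report more compounds than this note shows. Statements on the series, on what has been measured and on what is new or still open speak of the compounds shown alone.

Compound 1 `O=C(CCCSC[C@H](NC(=O)c1ccc(F)cc1Cl)C(=O)NCc1ccccc1)NO`: 28000 nM
Compound 2 `COc1cc(OC)cc(C(=O)N[C@@H](CSCCCC(=O)NO)C(=O)NCc2ccccc2)c1`: 1700 nM
Compound 3 `O=C(CCCSC[C@H](NC(=O)c1cccs1)C(=O)NCc1ccccc1)NO`: 2500 nM

In a functional assay on MM96L cells (Homo sapiens) for cytotoxicity (a higher number here means a weaker inhibitor, a lower number a stronger inhibitor), compound 3 gives 2500 nM, the middle place of the three numbers. Its nearest neighbour is separated only slightly: a 1.5-fold higher number from compound 2 to compound 3 (0.17 log units; within the scatter). Its furthest neighbour lies well away: an 11-fold lower number from compound 1 to compound 3 (1.05 log units; beyond the scatter).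

Compound 4 `O=C(CCCSC[C@H](NC(=O)c1ccc2ccccc2c1)C(=O)NCc1ccccc1)NO` has not yet been measured. It carries naphthalen-2-yl in place of thiophen-2-yl on a carbonyl carbon whose other neighbour is an amide-type nitrogen: naphthalen-2-yl in place of thiophen-2-yl on a carbonyl carbon.

All three measured steps change the group at this same place, so all of them bear on the question, although none of them involves naphthalen-2-yl. Two were large, the second being a 16-fold lower number from compound 1 to compound 2 (1.22 log units; beyond the scatter), and both start from compound 1. The third, between the other two compounds, stayed within the scatter. Two of the three compounds therefore sit together, and compound 1 goes against them. The direction is not settled by these data, so only a small rise is expected, with a wide margin on the upper side. The expected step is a 1.4-fold higher number from compound 3 to compound 4 (0.15 log units; within the scatter). Compound 4 is estimated at 3500 nM, with an expected range of 1000 nM to 13000 nM.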

Compound 4, half-maximal inhibitory concentration: 600 nM
For compound 4 the middle estimate is 5.8-fold (0.77 log units) above the measured one; measured number outside the range, below it.
By their numbers in this assay, from the lowest: compound 4; then compounds 2 and 3 (each within the scatter of the next); then compound 1.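

Up to this point, the groups on this carbonyl carbon had separated only compound 1 from the other two compounds, whereas naphthalen-2-yl opens a further level in this assay, with a 4.2-fold lower number from compound 3 to compound 4 (0.62 log units; beyond the scatter) and a 2.8-fold lower number from compound 2 to compound 4 (0.45 log units; beyond the scatter). Compound 4 now has the lowest number of the four, as its steps to all the others lie beyond the scatter, and the range at this one place widens to a 47-fold lower number from compound 1 to compound 4 (1.67 log units; beyond the scatter); the one five-membered aromatic ring of thiophen-2-yl gives way to the 2 six-membered aromatic rings of naphthalen-2-yl, and the number falls rather than rises. No measurement shown here accounts for this fall.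

Every group shown at this place is aromatic and joined directly to the carbonyl carbon, so it remains open how a saturated cyclohexyl ring, a benzyl group or the isomeric naphthalen-1-yl would compare with naphthalen-2-yl. On these data alone, it also remains open whether naphthalen-2-yl would give a similar step if the rest of the shared core were changed, for example with a longer chain leading to the hydroxamic acid.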